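Swapping 4-Phenoxybutyl for Isopropyl on the Nitrogen

A few compounds are considered here, and "the series" means these few. Any claim that something is new, unique, unknown or untested is made for them only; others in the source may bear on it.

Three measured compounds share one core and differ only in the group on a nitrogen on an aromatic ring. In a functional assay on PC-3 cells (Homo sapiens) for antiproliferative activity, read by MTT assay, with a stated time of 48 h (on this read-out higher numbers stand for weaker inhibition of growth and lower numbers for stronger inhibition of growth), compound 1 `Cc1ccc(-c2cnc(N(Cc3ccccc3)Cc3ccc(C(=O)NO)cc3)s2)cc1` gives 10400 nM as its reading, compound 2 `CCN(Cc1ccc(C(=O)NO)cc1)c1ncc(-c2ccc(C)cc2)s1` gives 10300 nM as its reading, and compound 3 `Cc1ccc(-c2cnc(N(CCCCOc3ccccc3)Cc3ccc(C(=O)NO)cc3)s2)cc1` gives 10300 nM as its reading. Compound 3 therefore stands level with compound 2 and within the scatter of compound 1.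

The next compound, compound 4 `Cc1ccc(-c2cnc(N(Cc3ccc(C(=O)NO)cc3)C(C)C)s2)cc1`, carries isopropyl in place of 4-phenoxybutyl on that nitrogen isopropyl in place of 4-phenoxybutyl on a nitrogen on an aromatic ring with the rest unchanged. All three measured steps bear on this swap, since each alters the same group: a 1.0-fold lower number from compound 1 to compound 2 (0.00 log units; within the scatter) and a 1.0-fold lower number from compound 1 to compound 3 (0.00 log units; within the scatter) and no change at the digits printed from compound 2 to compound 3 (within the scatter) are the whole evidence. Across these compounds, replacing the group has not moved the number beyond the scatter. Three compounds are a small base, however, and none of them carries isopropyl.

So in this assay no step beyond the scatter is expected. The estimated change is a 1.0-fold lower number from compound 3 to compound 4 (0.01 log units; within the scatter) and no more than that. For compound 4 the estimated value is 10000 nM with 5500 nM to 17000 nM as its expected range.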

Compound 4, concentration for 50% growth inhibition: 1150 nM
For compound 4 the middle estimate is 8.7-fold (0.94 log units) above the measured one; the measured number lies below the stated range.
By their numbers in this assay, from the lowest: compound 4; then compounds 2, 3 and 1 (each within the scatter of the next).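

The group on this nitrogen can move the number after all: in this assay, isopropyl in place of 4-phenoxybutyl gives a 9.0-fold lower number from compound 3 to compound 4 (0.95 log units; beyond the scatter), and isopropyl in place of benzyl gives a 9.0-fold lower number from compound 1 to compound 4 (0.96 log units; beyond the scatter). The change with the fewest added atoms, methyl in place of hydrogen on the saturated chain carbon bound to that nitrogen, gives a 9.0-fold lower number from compound 2 to compound 4 (0.95 log units; beyond the scatter), a step of much the same size, so among these compounds the size of the step does not follow the size of the group that leaves. Compound 4 is therefore the strongest inhibitor of growth of the four, while the other three remain within the scatter of one another.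

No measurement shown here explains why isopropyl stands apart from the other groups on this nitrogen. On these data alone, it also remains open whether this step is particular to isopropyl or would also appear with cyclopropyl or tert-butyl in the same place.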